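This account rests on a few compounds, and the source may have more. Where it says the series, first, only, none or still open, it means among the compounds named here.

Working notes on the series. For the measured compounds named here, compound 1 `Cc1noc(C)c1S(=O)(=O)N1CCC(N2CCC(C)CC2)CC1` is one of two compounds measured in an ADME assay on HCT-116 cells (Homo sapiens) for cytotoxicity, read by CellTiter-Glo, with a stated time of 72 h; on this read-out higher numbers stand for weaker inhibition and lower numbers for stronger inhibition. In this assay compound 1 gives > 10000 nM, which is a limit of the assay and not a number (the limit of > 10000 nM in this assay, at which 1 of the 2 values shown sits). Compound 2 `COc1ccc(-c2cccc(S(=O)(=O)N3CCC(N4CCC(C)CC4)CC3)c2)cc1` likewise returns only a limit: in this assay compound 2 gives > 5000 nM (the limit of > 5000 nM in this assay, at which 1 of the 2 values shown sits). With both values shown as limits, compound 2 stands nowhere in particular relative to compound 1. Compound 3 `COc1cccc(S(=O)(=O)N2CCC(N3CCC(C)CC3)CC2)c1` has yet to be measured in this assay; it differs from compound 2 by methoxy in place of 4-methoxyphenyl on an aromatic carbon. The step from compound 2 to compound 3 is expected to be a step that the limit leaves unreadable from compound 2 to compound 3, none beyond the scatter. Compound 3 is estimated at 20000 nM, with a range from 6000 nM to 60000 nM, most likely reported again as a limit.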

Compound 3, half-maximal inhibitory concentration: > 5000 nM
Compound 3 was reported as a limit (the forecaster's own chance of this, stated with the estimate: 85%); the middle value lies beyond the limit too.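

The steps from compound 2 to compound 3 and from compound 1 to compound 3 cannot be read, as each pair has only limits of the assay. The compounds shown leave open what concentration, if any, gives half-maximal inhibition in this assay.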